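Moving a methoxy group around a benzyl ring

The source may report more compounds than this note shows. Statements on the series, on what has been measured and on what is new or still open speak of the compounds shown alone.

Compound 2 `COc1ccccc1COc1ccccc1OCCNCCOc1c(OC)cccc1OC` is one of two compounds tested in a functional assay on thoracic aorta for antagonist activity at Alpha-1D adrenergic receptor (Rattus norvegicus); a higher number here means a more potent compound, by a factor of ten per unit of this negative logarithm, a lower number a less potent compound. Going by the values given here, compound 2 gives 8.86, and compound 1 `COc1cccc(OC)c1OCCNCCOc1ccccc1OCc1ccccc1C` gives 8.64; the only measured step, a number 0.22 log units higher from compound 1 to compound 2 (within the scatter), is too small to rank the two against each other. Compound 3 `COc1cccc(COc2ccccc2OCCNCCOc2c(OC)cccc2OC)c1` has not been measured yet. It differs from compound 2 by 3-methoxyphenyl in place of 2-methoxyphenyl on a saturated chain carbon bound to an oxygen on an aromatic ring: the same atoms are present, only the methoxy group sits at a different position of the benzyl ring. Among the compounds with values here, the one measured step, from compound 1 to compound 2, concerns a methyl becoming a methoxy on that same ring, not a shift of an existing group, so it does not speak directly to this change; it only shows that the ring tolerates some variation without a large effect. On that basis compound 3 is expected to land close to compound 2 in this assay, with an estimated step of a number 0.26 log units lower from compound 2 to compound 3 (within the scatter), with no direction beyond the scatter claimed. The estimate for compound 3 in this assay is therefore 8.6, with a range from 7.9 to 9.2.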

Compound 3, negative logarithm of the antagonist equilibrium constant: 9.12
Estimate against measurement, compound 3: 0.52 log units below, and the stated range covers the measured number.
By their numbers in this assay, from the lowest: compounds 1, 2 and 3 (each within the scatter of the next, the first and the last beyond it).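

In this assay the methoxy group can sit in either place on the benzyl ring, with a number 0.26 log units higher from compound 2 to compound 3 (within the scatter) being too small a step to tell 2-methoxyphenyl from 3-methoxyphenyl at this position on a saturated chain carbon bound to an oxygen on an aromatic ring. Going by these compounds alone, the new pair that does separate is the one with 3-methoxyphenyl in place of 2-methylphenyl, with a number 0.48 log units higher from compound 1 to compound 3 (beyond the scatter) as the first step in this small set to clear the scatter, though only modestly, so variation at this one position can move the number measurably, which compound 1 and compound 2 alone did not show. Nothing measured alongside these numbers accounts for them.

The compounds shown leave open what a hydroxy group, a chlorine or a longer ethoxy chain would do in place of the methoxy on 3-methoxyphenyl, since only methyl and methoxy appear on this ring. They also leave open whether the modest step from 2-methylphenyl to 3-methoxyphenyl would hold on a different core, as all three compounds share one.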